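A few compounds are considered here, and "the series" means these few. Any claim that something is new, unique, unknown or untested is made for them only; others in the source may bear on it.

Measured in a functional assay on MCF7 cells (Homo sapiens) for cytotoxicity; a higher number here means a weaker inhibitor, a lower number a stronger inhibitor:

- Compound 1 `COc1ccc(/C=C/c2cc(OC)c(OC)c(OC)c2)cc1B(O)O` gives 470 nM
- Compound 2 `COc1cc(/C=C/C(=O)c2cc(OC)c(OC)c(OC)c2)ccc1O` gives 110 nM
- Compound 3 `COc1cc(C(=O)/C=C/c2cc(OC)c(OC)c(OC)c2)ccc1B(O)O` gives > 2500 nM (a limit)

For compound 3 the result is a limit and not a number: > 2500 nM. Compound 4 `COc1cc(C(=O)/C=C/c2cc(OC)c(OC)c(OC)c2)ccc1O` has not yet been measured. It differs from compound 3 in one place: one oxygen atom in place of a group of 3 heavy atoms (1 boron, 2 oxygen; no ring), on an aromatic carbon. A hydroxy group, one oxygen atom, stands in place of a group of 3 heavy atoms (1 boron, 2 oxygen; no ring), on an aromatic carbon, ortho to a methoxy group and para to a large group.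

For the measured compounds named here, no two measured compounds differ in just one place, so this swap has no direct precedent here. Compound 2 also carries a hydroxy group and gives 110 nM, which leaves room for a gain. With a limit as the starting point, the size of the step cannot be fixed closely, and a modest move toward stronger inhibition is expected. The expected step is an at least 1.6-fold lower number from compound 3 to compound 4 (0.22 log units; that floor lies within the scatter). For compound 4 the estimated value is 1500 nM, with an expected range from 300 nM to 6000 nM.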

Compound 4, half-maximal inhibitory concentration: > 2500 nM
Compound 4: only a limit was reported; the forecaster's own chance of this, stated with the estimate: 35%; at least 1.6-fold (0.22 log units) between middle value and limit.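

For the compounds shown here, compound 3 and compound 4 each gave only a limit, not a number, so no step between them can be read, because both sit at the same limit: the limit of > 2500 nM in this assay, at which 2 of the 4 values shown sit. The compounds shown leave open whether swapping that boron-bearing group for hydroxy changes the true value at all, and in which direction.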